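Notes on the ring-amine substituent in a receptor-binding series

The source may hold more compounds than are shown below. What is called first, only, known or untested is meant among the compounds shown, and "the series" means these compounds.

Measured compounds:
compound 1 `CN(C(=O)N1CC[C@H](n2cnc3cc(-c4ccc(Cl)cc4)sc3c2=O)C1)[C@H]1CCNC1` gives 17 nM in an assay on isolated protein for binding affinity to melanin-concentrating hormone receptor 1 (Homo sapiens); a lower number here means a stronger inhibitor, a higher number a weaker inhibitor
compound 2 `CN(C(=O)N1CC[C@H](n2cnc3cc(-c4ccc(Cl)cc4)sc3c2=O)C1)[C@H]1CCN(C2CCC2)C1` gives 1 nM in this assay

For the measured compounds named here, compound 2 holds the lowest of the two numbers so far; its nearest neighbour is compound 1, and the only measured step, a 17-fold lower number from compound 1 to compound 2 (1.23 log units; beyond the scatter), shows how much the substituent on the amine nitrogen in a ring matters.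

Compound 3 `CN(C(=O)N1CC[C@H](n2cnc3cc(-c4ccc(Cl)cc4)sc3c2=O)C1)[C@H]1CCN(C2CCC(C)(C)CC2)C1` differs from compound 2 in that place: 4,4-dimethylcyclohexyl in place of cyclobutyl on an amine nitrogen in a ring. Going by the values given here, no measured step exchanges one carbon ring for another on that nitrogen, so the step from compound 1 to compound 2 bears only indirectly, as a sign that a carbon group on that nitrogen is well tolerated and strongly favourable. For compound 3 the expected step is a 1.5-fold higher number from compound 2 to compound 3 (0.18 log units; within the scatter), that is, no shift beyond the scatter in this assay. The estimate for compound 3 is 1.5 nM, within a range of 0.4 nM to 6 nM.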

Compound 3, inhibition constant: 2 nM
For compound 3 the middle estimate is 1.3-fold (0.12 log units) below the measured one; measured number inside the range.
By their numbers in this assay, from the lowest: compounds 2 and 3 (each within the scatter of the next); then compound 1.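

On the amine nitrogen in a ring, the substituent can grow from cyclobutyl to 4,4-dimethylcyclohexyl with no shift beyond the scatter in this assay (a 2.0-fold higher number from compound 2 to compound 3 (0.30 log units; within the scatter)), so a six-membered non-aromatic ring of carbon only serves as well here as a four-membered one. The gain over hydrogen on that nitrogen is thus not confined to cyclobutyl, as the second carbon ring also stands clear of the scatter (an 8.5-fold lower number from compound 1 to compound 3 (0.93 log units; beyond the scatter)). Nothing at hand explains why these two carbon rings give values within the scatter of each other.

On these data alone, both groups are plain carbon rings, so it remains open whether an acetyl group or a chain ending in a carboxylic acid on that nitrogen would hold this level. Also open, as far as these compounds go, is how far an open-chain group such as isopropyl would match the two rings.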